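The source may report more compounds than this note shows. Statements on the series, on what has been measured and on what is new or still open speak of the compounds shown alone.

Measured in a functional assay on cells (Neutrophil, Homo sapiens) for inhibition, with a stated time of 10 min; on this read-out lower numbers stand for stronger inhibition and higher numbers for weaker inhibition:
compound 1 `CCOC(=O)c1cnn(CC(C)O)c1NC(=O)NCc1ccccc1`: 0.00054 nM
compound 2 `CCOC(=O)c1cnn(CC(C)O)c1NC(=O)Nc1cccc(F)c1`: 0.0007 nM
compound 3 `CCOC(=O)c1cnn(CC(C)O)c1NC(=O)NC(C)C`: 0.00082 nM

In this assay, compound 1 sits in one tight group with compound 2 and compound 3. The gap to its nearest neighbour is a 1.3-fold higher number from compound 1 to compound 2 (0.11 log units; within the scatter), and the gap to its furthest is a 1.5-fold higher number from compound 1 to compound 3 (0.18 log units; within the scatter). The remaining pair shows a 1.2-fold higher number from compound 2 to compound 3 (0.07 log units; within the scatter).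

Compound 4 `CCOC(=O)c1cnn(CC(O)CC)c1NC(=O)NCc1ccccc1` keeps the shared core and the benzyl group of compound 1 but turns 2-hydroxypropyl into 2-hydroxybutyl. The change is methyl in place of hydrogen on a saturated chain carbon, two bonds along the chain from an oxygen on a saturated carbon.

For the measured compounds named here, all the measured steps exchange the group on an amide-type nitrogen, and none touches the chain that changes here, so the data hold no direct measure of this edit. They bear on it only loosely, by showing how narrow the range of values is so far. Replacing benzyl with isopropyl in compound 3 gave only a 1.5-fold higher number from compound 1 to compound 3 (0.18 log units; within the scatter). On that basis, no step beyond the scatter is expected in this assay, and no direction is favoured.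

The expected step is a 1.5-fold higher number from compound 1 to compound 4 (0.17 log units; within the scatter).

For compound 4 the estimated value is 0.0008 nM, with an expected range from 0.00025 nM to 0.003 nM.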

Compound 4, half-maximal inhibitory concentration: 0.0074 nM
Beside the measured number, compound 4's estimate is 9.3-fold (0.97 log units) below it; measured number above the stated range.
By their numbers in this assay, from the lowest: compounds 1, 2 and 3 (each within the scatter of the next); then compound 4.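

In this assay, the methyl that turns 2-hydroxypropyl into 2-hydroxybutyl gives a 14-fold higher number from compound 1 to compound 4 (1.14 log units; beyond the scatter), a large step beyond the scatter. The earlier compounds shown here showed no such sensitivity: benzyl, 3-fluorophenyl and isopropyl on the amide-type nitrogen stayed within the scatter of one another, with the widest gap being a 1.5-fold higher number from compound 1 to compound 3 (0.18 log units; within the scatter), whereas a single added carbon on the chain moves the number well outside that tight group. Nothing at hand accounts for the size of this step.

On these data alone, it remains open whether a longer chain, such as 2-hydroxypentyl, would raise the number further or whether the effect stops with the methyl, and whether an amine in place of the hydroxyl would change the picture. It is also unknown whether 3-fluorophenyl and isopropyl on the amide-type nitrogen would remain as interchangeable with benzyl on the 2-hydroxybutyl chain as they are on 2-hydroxypropyl.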